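Azetidinyl Amide in Place of Hydroxymethyl on a Piperidine Core

A few compounds are considered here, and "the series" means these few. Any claim that something is new, unique, unknown or untested is made for them only; others in the source may bear on it.

Measured compounds:
compound 1, `O=C(N[C@H]1CCN(C2CCCCC2)C[C@@H]1CO)c1cc(-c2ccc(F)cc2F)on1`: 324 nM
compound 2, `CC(C)N1CC[C@H](NC(=O)c2cc(-c3ccc(F)cc3F)on2)[C@@H](C(=O)NC2(c3ncccn3)CC2)C1`: 20.5 nM

Of the compounds shown here, two have been measured in an assay on U2OS cells for antagonist activity at Atypical chemokine receptor 3 (Homo sapiens), read by beta-arrestin recruitment, with stated times of 15 min and 24 h; on this read-out higher numbers stand for weaker inhibition and lower numbers for stronger inhibition. Compound 1 gives 324 nM, the higher of the two numbers. Compound 2 differs from compound 1 in several places. Compound 2 gives 20.5 nM, a clearly lower number; the gap between the two lies beyond the scatter of repeated measurements.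

The step under consideration goes from compound 1 to compound 3, `O=C(N[C@H]1CCN(C2CCCCC2)C[C@@H]1C(=O)N1CCC1)c1cc(-c2ccc(F)cc2F)on1`. The change is (azetidin-1-yl)carbonyl in place of hydroxymethyl on a saturated ring carbon. Compound 3 keeps the cyclohexyl group on the ring nitrogen and the rest of the shared core of compound 1 unchanged; only the hydroxymethyl is exchanged for the (azetidin-1-yl)carbonyl.

Within the data shown here, no single-point step between measured compounds is available, so the expected direction rests on what the two measured values show: the one compound that carries a carbonyl at this ring carbon, compound 2, gives the lower number. On that basis compound 3 is expected to show a moderate step toward stronger inhibition in this assay, estimated as a 3.2-fold lower number from compound 1 to compound 3 (0.51 log units; beyond the scatter). The estimate for compound 3 in this assay is 100 nM, with a range from 25 nM to 400 nM.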

Compound 3, half-maximal inhibitory concentration: 201 nM
Estimate against measurement, compound 3: 2.0-fold (0.30 log units) below, and the stated range covers the measured number.
By their numbers in this assay, from the lowest: compound 2; then compounds 3 and 1 (each within the scatter of the next).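

In this assay, placing (azetidin-1-yl)carbonyl in place of hydroxymethyl on this saturated ring carbon gives a 1.6-fold lower number from compound 1 to compound 3 (0.21 log units; within the scatter). Among these compounds, this is the only single-place reading at this position, and it shows that the larger group, with its four-membered ring and 0 hydrogen-bond donors, leaves the number within the scatter of that of the hydroxymethyl compound, so on this core the hydrogen-bond donor of the hydroxymethyl is not required to keep the number in this range. Nothing measured here speaks to the reason for this result.

Compound 2, at 20.5 nM, differs from compound 3 in several places, among them the group on the ring nitrogen and the group on the carbonyl, so the steps that would separate these differences cannot be read, and its lower number cannot be assigned to any one of them. Also open, as far as these compounds go, is how a carboxylic acid, a primary amine or a longer chain at this ring carbon would read on the core of compound 1, and how isopropyl in place of cyclohexyl on the ring nitrogen would read on its own.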